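The source may hold more compounds than are shown below. What is called first, only, known or untested is meant among the compounds shown, and "the series" means these compounds.

Compound 1 `CCOC(=O)c1cccc(-c2ccc(N(C)C)cc2)c1` gives 87% in an assay on COS-7 cells for inhibition of patatin-like phospholipase domain-containing protein 2 (Mus musculus), tested at 200 uM; on this read-out higher numbers stand for more inhibition at the one concentration tested (going by the name of the read-out) and lower numbers for less inhibition.
Compound 2 `CCOC(=O)c1cccc(-c2ccc(CN3CCCC3)cc2)c1` gives 33% in this assay.
Compound 3 `CCOC(=O)c1cccc(-c2ccc(C(C)N(C)C)cc2)c1` gives 50% in this assay.

Compound 1 stands highest of the three numbers in this assay. Its nearest neighbour is compound 3, with a number 37 percentage points lower from compound 1 to compound 3 (beyond the scatter), and its furthest is compound 2, with a number 54 percentage points lower from compound 1 to compound 2 (beyond the scatter); between those two, a number 17 percentage points higher from compound 2 to compound 3 (beyond the scatter). All three measured steps alter the amine-bearing side of the shared core while the ethoxycarbonyl group stays fixed.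

Compound 4 `CN(C)c1ccc(-c2cccc(NC(=O)C(C)(C)C)c2)cc1` has not yet been measured in this assay. It keeps the dimethylamino group of compound 1 and differs as follows: ((tert-butyl)carbonyl)amino in place of ethoxycarbonyl on an aromatic carbon.

Among the measured compounds shown here, none of the measured steps touches the ethoxycarbonyl group, so no step bears directly on this change; the measured series only shows that the shared core with a dimethylamino group can reach the number of compound 1 in this assay. For the measured compounds named here, with no comparable step to lean on, the expected step is a number 32 percentage points lower from compound 1 to compound 4 (beyond the scatter), a decrease beyond the scatter but with wide uncertainty. For compound 4 the estimated value in this assay is 55%, expected to lie between 15% and 90%.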

Compound 4, a percentage reported as inhibition, at one concentration (the size of the read-out at that concentration, not a potency): 25%
Estimate against measurement, compound 4: 30 percentage points above; the range from low to high includes it.
By their numbers in this assay, from the lowest: compounds 4 and 2 (each within the scatter of the next); then compound 3; then compound 1.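

In this assay, putting ((tert-butyl)carbonyl)amino in place of ethoxycarbonyl, with the dimethylamino group kept, comes with a number 62 percentage points lower from compound 1 to compound 4 (beyond the scatter) and so is a large step. Among the compounds shown here, it is the only measured change at this position, on an aromatic carbon meta to a group of 9 heavy atoms, and it shows that the number in this assay responds to what sits here as well as to the amine-bearing side, the only part the earlier steps varied. The entering group differs from the one it replaces in heavy atoms and hydrogen-bond donors, but the data given do not say which difference, if any, accounts for the step.

The compounds shown leave open whether the step belongs to the amide link, to the tert-butyl group or to the loss of the ethyl ester, which a carboxylic acid, an acetylamino group or a primary amine at this place could help to separate. They also leave open whether the same exchange gives a step of similar size with (pyrrolidin-1-yl)methyl or 1-(dimethylamino)ethyl in place of the dimethylamino group.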